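Working notes: chloro to methoxy swap on a shared core

The compounds below may be only part of what the source reports. "The series", "measured", "known", "first", "only" and "open" are said of these compounds alone.

Measured compounds:
compound 1 `Nc1sc(-c2ccc(Cl)cc2)c(-c2cccc(C(F)(F)F)c2)c1C(=O)c1ccccc1`: > 10 uM, a limit of the assay
compound 2 `COc1ccc(-c2sc(N)c(C(=O)c3ccccc3)c2-c2cccc(C(F)(F)F)c2)cc1`: > 10 uM, a limit of the assay
compound 3 `CCOC(=O)c1c(N)sc(-c2ccc(Cl)cc2)c1-c1cccc(C(F)(F)F)c1`: 6.6 uM

Compound 1 stops at the limit of > 10 uM in this assay, at which 2 of the 3 values shown sit, a limit and not a number. Compound 2 stops at that same limit. For the measured compounds named here, in a functional assay on CHO-K1 cells for agonist activity at adenosine receptor A1 (Homo sapiens), read by GTPgammaS binding (on this read-out lower numbers stand for an effect already at smaller amounts and higher numbers for an effect only at larger amounts of compound), compound 3 gives 6.6 uM, the only number in the set. Compound 3 differs from compound 1 by ethoxy in place of phenyl on a carbonyl carbon; the step of an at least 1.5-fold lower number from compound 1 to compound 3 (0.18 log units; that floor lies within the scatter), so the gain cannot be separated from scatter. Compound 2 differs from compound 1 by methoxy in place of chloro on an aromatic carbon; the step that the two limits leave unreadable from compound 1 to compound 2, as both readings are limits.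

Compound 4 `CCOC(=O)c1c(N)sc(-c2ccc(OC)cc2)c1-c1cccc(C(F)(F)F)c1` is not yet measured. It differs from compound 3 by methoxy in place of chloro on an aromatic carbon, the same change as from compound 1 to compound 2, the place being identical in both; only the cores differ, as described above. The earlier step gives no readable size, so the expectation rests on compound 3 with 6.6 uM and on the unreadable step that the two limits leave unreadable from compound 1 to compound 2. For compound 4 the expected step is a 1.2-fold higher number from compound 3 to compound 4 (0.08 log units; within the scatter). The estimate for compound 4 is 8 uM, expected between 3 uM and 25 uM, with a fair chance that only a limit is returned.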

Compound 4, concentration for half-maximal effect: > 10 uM
Compound 4: a limit, no number (the forecaster's own chance of this, stated with the estimate: 40%); middle value at least 1.2-fold (0.09 log units) away from the limit.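

In this assay compound 4 gives > 10 uM, a limit of the assay and not a number. Methoxy in place of chloro on the core of compound 3 gives an at least 1.5-fold higher number from compound 3 to compound 4 (0.18 log units; that floor lies within the scatter), so any rise cannot be separated from scatter, and the steps from compound 1 to compound 2 and from compound 2 to compound 4 cannot be read. The methoxy compounds on both cores stop at the same limit, which fits a transfer of the change but neither confirms it nor gives a size to compare between the cores, because the readings end there: the limit of > 10 uM in this assay, at which 3 of the 4 values shown sit.

The compounds shown leave open whether a group other than chloro on the same aromatic carbon, such as fluoro, hydroxyl or an amine, would give a readable number on the core of compound 3. Also open, from the compounds shown here alone, is how a carboxylic acid or a longer chain in place of the ethoxy on the carbonyl carbon would read.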